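A few compounds are considered here, and "the series" means these few. Any claim that something is new, unique, unknown or untested is made for them only; others in the source may bear on it.

Compound 3 `N#CC1=C(N)Oc2c(c3nc4ccccc4nc3c3ccccc23)C12C(=O)N(Cc1cnnn1-c1ccc([N+](=O)[O-])cc1)c1ccccc12` is one of three close relatives that differ only in the aryl group attached to an aromatic nitrogen. In an ADME assay on L02 cells (Homo sapiens) for antiproliferative activity, read by MTT assay, with a stated time of 48 h (a higher number here means a weaker inhibitor, a lower number a stronger inhibitor), compound 3 gives > 50000 nM, which is a limit of the assay rather than a number. Compound 1 `N#CC1=C(N)Oc2c(c3nc4ccccc4nc3c3ccccc23)C12C(=O)N(Cc1cnnn1-c1ccccc1Cl)c1ccccc12` gives > 50000 nM, also a limit. Compound 2 `N#CC1=C(N)Oc2c(c3nc4ccccc4nc3c3ccccc23)C12C(=O)N(Cc1cnnn1-c1ccc(Br)cc1)c1ccccc12` gives > 50000 nM, again a limit. Compound 3 therefore stands together with both others at the limit of > 50000 nM in this assay, at which 3 of the 3 values shown sit. Compound 4 `N#CC1=C(N)Oc2c(c3nc4ccccc4nc3c3ccccc23)C12C(=O)N(Cc1cnnn1-c1ccc(F)c(Cl)c1)c1ccccc12` differs from compound 3 in one place: 3-chloro-4-fluorophenyl in place of 4-nitrophenyl on an aromatic nitrogen. The comparable changes of the aryl group, a step that the two limits leave unreadable from compound 1 to compound 3 and a step that the two limits leave unreadable from compound 2 to compound 3, and likewise a step that the two limits leave unreadable from compound 1 to compound 2, have no readable size, so no direction can be drawn from them. Compound 4 is therefore expected to give 60000 nM, between 30000 nM and 150000 nM, most likely again as a limit. The step that the limit leaves unreadable from compound 3 to compound 4 is expected to stay within the scatter.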

Compound 4, half-maximal inhibitory concentration: > 50000 nM
Compound 4 ended at the assay's limit; the forecaster's own chance of this, stated with the estimate: 85%; the middle value lies beyond the limit too.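

No step can be read among compound 1, compound 2, compound 3 and compound 4, since all share one limit rather than a number: the limit of > 50000 nM in this assay, at which 4 of the 4 values shown sit. On these data alone, whether these aryl groups differ at all in this assay stays open.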